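The source may report more compounds than this note shows. Statements on the series, on what has been measured and on what is new or still open speak of the compounds shown alone.

Working notes on the series. Compound 1 `COC(=O)c1ccc(CCCCCCC(=O)c2ncc(-c3ccccn3)o2)cc1`, compound 2 `O=C(CCCCCCc1ccc(Cl)cc1)c1ncc(-c2ccccn2)o1` and compound 3 `CC(C)(C)OC(=O)Nc1ccc(CCCCCCC(=O)c2ncc(-c3ccccn3)o2)cc1` share one core and differ only in the group carried on the aromatic ring at the far end of the chain. In an assay for inhibition of Fatty-acid amide hydrolase 1 (Rattus norvegicus) (a higher number here means a weaker inhibitor, a lower number a stronger inhibitor), compound 1 gives 1.5 nM, compound 2 gives 2.7 nM and compound 3 gives 5.6 nM. Compound 2 stands second of the three numbers in this assay: the step of a 1.8-fold higher number from compound 1 to compound 2 (0.26 log units; within the scatter), the step of a 2.1-fold higher number from compound 2 to compound 3 (0.32 log units; beyond the scatter), and across the pair a 3.7-fold higher number from compound 1 to compound 3 (0.57 log units; beyond the scatter).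

Compound 4 `CSc1cccc(CCCCCCC(=O)c2ncc(-c3ccccn3)o2)c1` is not yet measured. Relative to compound 2 the change is 3-(methylsulfanyl)phenyl in place of 4-chlorophenyl on a saturated chain carbon, six bonds along the chain from a carbonyl carbon. The three measured steps all swap the group on this same ring and so bear on it; every one of them was small, the largest only modest. Going by the values given here, no measured compound carries a 3-(methylsulfanyl)phenyl group, so the expectation rests only on how little the ring swaps seen so far moved the number. For compound 4 the expected step in this assay is a 1.5-fold higher number from compound 2 to compound 4 (0.17 log units; within the scatter), with no clear direction beyond the scatter. Compound 4 is therefore estimated at 4 nM in this assay, within a range of 1.5 nM to 12 nM.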

Compound 4, inhibition constant: 4.2 nM
Estimate against measurement, compound 4: 1.1-fold (0.02 log units) below; the measured number falls inside the stated range.
By their numbers in this assay, from the lowest: compounds 1, 2, 4 and 3 (each within the scatter of the next, the first and the last beyond it).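

In this assay the step of a 1.6-fold higher number from compound 2 to compound 4 (0.19 log units; within the scatter) is the only one shown that changes both the identity of the ring substituent and its numbered place, as 3-(methylsulfanyl)phenyl enters in place of 4-chlorophenyl. The two compounds cannot be told apart here, so the tolerance seen in the earlier swaps, which kept the substituent in one ring place, also holds for this double change at the end of the chain. No measurement shown bears on why the number holds across this change.

The step joins two changes, so the compounds shown leave open what each contributes alone; 3-chlorophenyl and 4-(methylsulfanyl)phenyl would separate the identity of the group from its place on the ring. On these data alone, it also remains open whether this tolerance extends to a carboxylic acid or an amine on the same ring, or to a longer chain between the ring and the carbonyl.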